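The source may hold more compounds than are shown below. What is called first, only, known or untested is meant among the compounds shown, and "the series" means these compounds.

Among the measured compounds shown here, in a functional assay on the whole organism (strain Sprague-Dawley) for inhibition, with Rattus norvegicus as the target, with a stated time of 10 min (on this read-out higher numbers stand for an effect only at larger amounts of compound and lower numbers for an effect already at smaller amounts), only one number is available so far for this small series. Compound 1 (`CCOC(=O)c1cnc(-c2ccccc2N)[nH]c1=O`) has "not determined" (no result reported), so it offers nothing to compare against. Compound 2 (`C=CCOc1ccccc1-c1ncc(C(=O)OCC)c(=O)[nH]1`) gives 0.5 mg/kg, and as the only number shown it cannot yet be ranked as strong or weak within the series. Compound 3 (`CCOC(=O)c1cnc(-c2ccccc2SC)[nH]c1=O`) keeps the core of compound 2 and changes one group: methylsulfanyl in place of allyloxy on an aromatic carbon, ortho to a large group (methylsulfanyl in place of allyloxy on an aromatic carbon). For the measured compounds named here, no measured pair shows what such a swap does, so the expectation is only a guess from the change itself: a small shift towards a larger dose, perhaps none beyond the usual scatter. The estimate means an expected 1.6-fold higher number from compound 2 to compound 3 (0.20 log units; within the scatter). For compound 3 the expected dose is 0.8 mg/kg, with an estimated range of 0.2 mg/kg to 3 mg/kg.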

Compound 3, dose for 50% inhibition: > 25 mg/kg
Compound 3 ended at the assay's limit (the forecaster's own chance of this, stated with the estimate: 10%); middle value at least 31-fold (1.49 log units) away from the limit.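

In this assay, among the compounds shown here, the first readable step at this place on the aromatic ring, an at least 50-fold higher number from compound 2 to compound 3 (1.69 log units; beyond the scatter), shows that the group here matters a great deal. Allyloxy and methylsulfanyl match in their counts of hydrogen-bond donors and acceptors, yet the results lie far apart, so those counts alone do not predict the outcome at this position. Compound 3 stands at a limit rather than at a number: the limit of > 25 mg/kg in this assay, at which 1 of the 3 values shown sits.

The swap changes several things at once: sulfur replaces oxygen, and the chain becomes shorter and loses its double bond. The compounds shown cannot say which of these matters, whereas a methoxy group at this place would keep the oxygen with a short chain, and a propyloxy group would keep the chain length without the double bond.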